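Anilide series against sirtuin-6: alkyl replaces thiophene

The compounds below may be only part of what the source reports. "The series", "measured", "known", "first", "only" and "open" are said of these compounds alone.

Among the measured compounds shown here, compound 1 `O=C(O)c1cccc(NC(=O)c2cccc(N3C(=O)CCS3(=O)=O)c2)c1` is the only member with a number so far: in an assay on isolated protein for inhibition of NAD-dependent protein deacylase sirtuin-6 (Homo sapiens), read by fluorescence, tested at 200 uM (on this read-out lower numbers stand for less inhibition and higher numbers for more inhibition at the one concentration tested (going by the name of the read-out)), compound 1 gives 5%. Compound 2 `O=C(Cc1cccs1)Nc1cccc(C(=O)Nc2cccc(C(=O)O)c2)c1`, which carries the same benzoic acid anilide core, is reported in this assay only as "not active" (no number reported), with no figure attached, so compound 2 stands at the weak end of the series without a fixed position on the scale. Compound 3 `CCC(CC)C(=O)Nc1cccc(C(=O)Nc2cccc(C(=O)O)c2)c1` differs from compound 2 in one place, (pentan-3-yl in place of (thiophen-2-yl)methyl on a carbonyl carbon), a change that removes the ring and its acceptor while the rest of the molecule is kept. Nothing measured links an alkyl and an aryl group at this carbonyl, so no direction can be read from the data. The step from compound 2 to compound 3 in this assay is expected to stay within the scatter, with no real gain. Compound 3 is estimated at 5% in this assay, within a range of 0% to 15%.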

Compound 3, a percentage reported as inhibition, at one concentration (the size of the read-out at that concentration, not a potency): 54%
Compound 3: middle estimate off by 49 percentage points, on the low side, outside the stated range (above it).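

In this assay compound 3, with pentan-3-yl on the carbonyl carbon, has a real number, while compound 2, with (thiophen-2-yl)methyl at that place, stands as "not active" (no number reported) with no figure, so the size of this change cannot be read. Among the compounds shown here, the one step that can be read, a number 49 percentage points higher from compound 1 to compound 3 (beyond the scatter), shows that the group on the aromatic carbon of the shared core can move this read-out strongly. It also shows that no ring is needed in that group for inhibition at the one concentration tested. Nothing available accounts for the rise.

Open, as far as these compounds go, is whether a longer chain, a cyclohexyl ring or an amine at this carbonyl holds the read-out at the level of compound 3. Also open, from the compounds shown here alone, is how a plain phenyl ring on this carbonyl compares with the thiophene-bearing group of compound 2.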